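The compounds below may be only part of what the source reports. "The series", "measured", "known", "first", "only" and "open" are said of these compounds alone.

Compound 1 `CC[C@H](C)[C@H](NC(=O)c1cccc(Cn2ccnc2)c1)C(=O)NNS(=O)(=O)c1ccc(OC)cc1`, compound 2 `CC[C@H](C)[C@H](NC(=O)c1cccc(Cn2ccnc2)c1)C(=O)NNS(=O)(=O)c1c(C)cc(C)cc1C`, compound 3 `CC[C@H](C)[C@H](NC(=O)c1cccc(Cn2ccnc2)c1)C(=O)NNC(=O)OC(C)(C)C`, compound 4 `CCCCCS(=O)(=O)NNC(=O)[C@@H](NC(=O)c1cccc(Cn2ccnc2)c1)[C@@H](C)CC`.

In an assay on HEK293 cells for displacement of a labelled ligand from Type-2 angiotensin II receptor (Homo sapiens) (on this read-out higher numbers stand for weaker inhibition and lower numbers for stronger inhibition), compound 1 gives 9200 nM. In this assay compound 2 gives 8500 nM, a change of a 1.1-fold lower number from compound 1 to compound 2 (0.03 log units; within the scatter). For compound 3 the assay reports only a limit, > 100000 nM, so compound 3 stands at the limit of > 100000 nM in this assay, at which 1 of the 3 values shown sits. The step from compound 3 to compound 4 is pentylsulfonyl in place of tert-butoxycarbonyl on an amine nitrogen. The measured steps that bear on it run the other way: an at least 10-fold higher number from compound 1 to compound 3 (1.03 log units; beyond the scatter) and an at least 11-fold higher number from compound 2 to compound 3 (1.07 log units; beyond the scatter), both large. Bringing back a sulfonyl group is therefore expected to lower the number, although no measured step sets a pentylsulfonyl group against an arylsulfonyl one. Compound 4 is expected to show an at least 5.0-fold lower number from compound 3 to compound 4 (0.69 log units; beyond the scatter). The estimate for compound 4 is 20000 nM, within 7000 nM to 100000 nM.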

Compound 4, inhibition constant: > 100000 nM
Compound 4 was reported as a limit (the forecaster's own chance of this, stated with the estimate: 25%); middle value at least 5.0-fold (0.69 log units) from the limit.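

A sulfonyl group on this amine nitrogen is not enough on its own, as the group carried on the sulfonyl sulfur also counts: with pentyl there, the steps are an at least 10-fold higher number from compound 1 to compound 4 (1.03 log units; beyond the scatter) and an at least 11-fold higher number from compound 2 to compound 4 (1.07 log units; beyond the scatter). The step between compound 3 and compound 4 cannot be read. In this assay compound 4 is reported only as a limit, the same one as compound 3: the limit of > 100000 nM in this assay, at which 2 of the 4 values shown sit.

Left open is how far compound 3 and compound 4 lie past that limit. As far as these compounds go, it is also open whether a cyclohexyl or benzyl group on the sulfonyl sulfur would behave like the 4-methoxyphenyl of compound 1 or the pentyl of compound 4.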